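The source may hold more compounds than are shown below. What is called first, only, known or untested is meant among the compounds shown, and "the series" means these compounds.

Compound 1 `O=C1OC2(c3ccccc3)CCCCCN1C2=O` gives 66 mg/kg in a functional assay on the whole organism with Mus musculus as the target, in the maximal electroshock model, with a stated time of 0.5 h; a higher number here means that more compound is needed for the effect, a lower number that less compound is needed.
Compound 2 `CCC1(c2ccccc2)OC(=O)NC1=O` gives 86 mg/kg.
Compound 3 `O=C1O[C@@]2(c3ccccc3)CCCCCN1C2=O` gives 45 mg/kg.

Among these three, compound 2 has the highest number, but its gap to compound 1 and its gap to compound 3 both lie within the scatter, so the three cannot be placed in an order. Compound 4 `CC[C@@]1(c2ccccc2)OC(=O)NC1=O` has not yet been measured. It differs from compound 2 only in the drawing of stereochemistry: the two compounds have the same atoms and bonds; at least one stereo element is drawn with a configuration in one of them and without one in the other: 1 of 1 stereo elements differ; a stereocentre at a saturated ring carbon is drawn without a configuration in compound 2 and S in compound 4. One measured step is of the same kind, the step of a 1.5-fold lower number from compound 1 to compound 3 (0.17 log units; within the scatter), where the two compounds share all atoms and bonds and differ only in that (the fact that one of compounds 1 and 3 is drawn with a defined configuration and the other without, at the place where they differ). That step stayed within the scatter. The change from compound 2 to compound 4 is therefore expected to give at most a small shift, if any, with a slight lean toward a lower number in line with the measured pair, that is an expected step of a 1.2-fold lower number from compound 2 to compound 4 (0.09 log units; within the scatter). Compound 4 is thus expected to give about 70 mg/kg, with a likely range from 40 mg/kg to 130 mg/kg.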

Compound 4, dose for half-maximal effect: 141 mg/kg
The estimate for compound 4 lay 2.0-fold (0.30 log units) below the measured number, outside the stated range (above it).
By their numbers in this assay, from the lowest: compounds 3, 1, 2 and 4 (each within the scatter of the next, the first and the last beyond it).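

In this assay, the second change of this kind, a 1.6-fold higher number from compound 2 to compound 4 (0.21 log units; within the scatter), again stays within the scatter, as did a 1.5-fold lower number from compound 1 to compound 3 (0.17 log units; within the scatter), so on two different cores a defined configuration at this stereocentre has not moved the number beyond the scatter. The two steps point in opposite directions, so the slight lean toward a lower number seen in the first pair does not carry over, and no direction can be assigned to this change. The new pair rests on the same kind of difference as the earlier one: the fact that one of compounds 2 and 4 is drawn with a defined configuration and the other without, at the place where they differ

As far as these compounds go, compound 3 is drawn R and compound 4 is drawn S, on different cores, so how the two opposite configurations compare on a single core remains open. Also open, from the compounds shown here alone, is how a longer chain or a carboxylic acid in place of the ethyl group of compound 4 would behave at this stereocentre.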